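The source may report more compounds than this note shows. Statements on the series, on what has been measured and on what is new or still open speak of the compounds shown alone.

In an ADME assay on MRC5 cells (Homo sapiens) for inhibition, with a stated time of 72 h (a higher number here means that more compound is needed for the effect, a lower number that less compound is needed), compound 1 `CO[C@H]1CC[C@H](NC(=O)c2n[nH]cc2NC(=O)c2ccc(F)cc2F)CC1` gives 11000 nM. Compound 2 `COc1cccc(OC)c1C(=O)Nc1c[nH]nc1C(=O)NC1CC1` returns only the limit of the measurement, > 50000 nM. Compound 3 `COc1cc(OC)c(C(=O)Nc2c[nH]nc2C(=O)N[C@H]2CC[C@H](OC)CC2)c(OC)c1` likewise returns only a limit, > 50000 nM. Compound 2 therefore stands at the top of the measured range without a number of its own, a position it shares with another of the three compounds (the limit of > 50000 nM in this assay, at which 2 of the 3 values shown sit). Compound 4 `COc1cccc(OC)c1C(=O)Nc1c[nH]nc1C(=O)NCc1ccccc1` has not yet been measured in this assay. It differs from compound 2 in one place: benzyl in place of cyclopropyl on an amide-type nitrogen. Among the compounds with values here, no measured step matches this change, so the expected step of a number no higher from compound 2 to compound 4 (the limit leaves the size open) is no larger than the scatter, and the value is expected to remain at or near the limit. For compound 4 the estimate in this assay is 50000 nM, within a range from 15000 nM to 150000 nM.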

Compound 4, half-maximal effective concentration: 50000 nM
Compound 4: middle estimate and measured number agree at the digits printed; measured number inside the range.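

In this assay, benzyl in place of cyclopropyl on the amide-type nitrogen gives a number no higher from compound 2 to compound 4 (the limit leaves the size open). Compound 4 thus gives a readable number, 50000 nM, and shows that this position carries an aromatic ring without the number rising past what compound 2 allows. The size of the step cannot be read because one end of it is only a limit: the limit of > 50000 nM in this assay, at which 2 of the 4 values shown sit.

The compounds shown leave open how far compound 2 lies from compound 4. They also leave open whether an amine or a carboxylic acid at this nitrogen would lower the number.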